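This account rests on a few compounds, and the source may have more. Where it says the series, first, only, none or still open, it means among the compounds named here.

Compound 1 `CCOC(=O)c1sc2nc(-c3ccccc3)cc(C(F)(F)F)c2c1N`: > 20000 nM
Compound 2 `CCOC(=O)c1sc2nc(-c3cccs3)cc(C(F)(F)F)c2c1N`: > 20000 nM
Compound 3 `CCOC(=O)c1sc2nc(C3CC3)cc(C(F)(F)F)c2c1N`: > 20000 nM

Three compounds sharing one core were tested in an ADME assay on Huh-7 cells (Homo sapiens) for cytotoxicity, read by MTT assay, with a stated time of 72 h; a higher number here means that more compound is tolerated, a lower number that less compound is tolerated. In this assay compound 1 gives > 20000 nM, which is a limit of the assay rather than a number. Compound 2 gives > 20000 nM, again a limit. Compound 3 gives > 20000 nM, also a limit. Compound 3 therefore stands at the same limit as the other two, and no order among the three can be read, since (the limit of > 20000 nM in this assay, at which 3 of the 3 values shown sit).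

The step to compound 4 `CCOC(=O)c1sc2nc(-c3ccco3)cc(C(F)(F)F)c2c1N` changes the cyclopropyl of compound 3: furan-2-yl in place of cyclopropyl on an aromatic carbon. Of the measured steps, those at this same position bear on it: a step that the two limits leave unreadable from compound 1 to compound 3, a step that the two limits leave unreadable from compound 2 to compound 3 and a step that the two limits leave unreadable from compound 1 to compound 2. Each of them runs between two limits, so none of them shows a readable size, and none gives a direction. Exchanging phenyl, thiophen-2-yl and cyclopropyl at this position kept every value at the limit, and a furan-2-yl is the only new entry here.

The expectation for compound 4 in this assay is thus a step that the limit leaves unreadable from compound 3 to compound 4 beyond compound 3, most likely again only a limit. Compound 4 is estimated at 30000 nM, within a range from 15000 nM to 80000 nM.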

Compound 4, half-maximal cytotoxic concentration: > 20000 nM
Compound 4 was reported as a limit; the forecaster's own chance of this, stated with the estimate: 85%; the middle value does not contradict the limit.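

In this assay compound 4 gives > 20000 nM as a limit and not a number. Its steps to compound 1, compound 2 and compound 3 therefore cannot be read, and no order among the four can be given: the limit of > 20000 nM in this assay, at which 4 of the 4 values shown sit. The compounds shown leave open whether these four differ at all in how much compound is tolerated, and which change at this position, if any, would bring a value within the measurable range.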